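Bromo to Cyano Exchange on Two Related Sulfonamide Cores

The source may hold more compounds than are shown below. What is called first, only, known or untested is meant among the compounds shown, and "the series" means these compounds.

Measured so far in an ADME assay on L02 cells (Homo sapiens) for cytotoxicity, read by MTT assay, with a stated time of 24 h; a lower number here means a stronger inhibitor, a higher number a weaker inhibitor:
compound 1 `O=C1/C(=C/c2ccccc2F)CN(S(=O)(=O)c2ccc(Br)cc2)C/C1=C\c1ccccc1F` gives 16200 nM
compound 2 `N#Cc1ccc(S(=O)(=O)N2C/C(=C\c3ccccc3F)C(=O)/C(=C/c3ccccc3F)C2)cc1` gives 11000 nM
compound 3 `O=C1/C(=C/c2ccc(F)cc2)CN(S(=O)(=O)c2ccc(Br)cc2)C/C1=C\c1ccc(F)cc1` gives 16400 nM

Compound 2 differs from compound 1 by cyano in place of bromo on an aromatic carbon. That change gave a 1.5-fold lower number from compound 1 to compound 2 (0.17 log units; within the scatter). Compound 3 is built from the same atoms as compound 1, joined differently; the difference between the two cores is not broken down here. The values of compound 1 and compound 3 in this assay lie within the scatter of each other, so no order between them can be read.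

Compound 4 `N#Cc1ccc(S(=O)(=O)N2C/C(=C\c3ccc(F)cc3)C(=O)/C(=C/c3ccc(F)cc3)C2)cc1` has not yet been measured. It differs from compound 3 by cyano in place of bromo on an aromatic carbon, which is the same change, at the same place, as that from compound 1 to compound 2. Among the compounds with values here, the only guide to its size is the earlier pair: resting on a 1.5-fold lower number from compound 1 to compound 2 (0.17 log units; within the scatter), the step is expected to be small, roughly a 1.4-fold lower number from compound 3 to compound 4 (0.15 log units; within the scatter). On that basis compound 4 is estimated at 11500 nM in this assay, with an expected range from 6000 nM to 22000 nM.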

Compound 4, half-maximal inhibitory concentration: 14700 nM
The estimate for compound 4 lay 1.3-fold (0.11 log units) below the measured number, and the stated range covers the measured number.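

In this assay, cyano in place of bromo on the core of compound 3 gave a 1.1-fold lower number from compound 3 to compound 4 (0.05 log units; within the scatter), a step that lies within the scatter, as did the earlier one. Set side by side, the two steps cannot be told apart: the same change on two cores in this assay, a 1.5-fold lower number (0.17 log units; within the scatter) from compound 1 to compound 2 and a 1.1-fold lower number (0.05 log units; within the scatter) from compound 3 to compound 4, 1.3-fold (0.12 log units) apart, within the scatter of two such steps. This shows that the change carried from one core to the other without a readable difference in size, but neither step is beyond the scatter, so it does not show that cyano and bromo differ in this assay, and two cores are too few to support a rule for the whole series.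

The compounds shown leave open whether a different group on the same aromatic carbon, such as an amine or a carboxylic acid, would shift the number beyond the scatter. They also leave open how the same exchange behaves on a core that carries chloro in place of fluoro.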